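Swapping Fluoro for Methoxy: Expected Change in Clearance

This account rests on a few compounds, and the source may have more. Where it says the series, first, only, none or still open, it means among the compounds named here.

Measured compounds and their values:
compound 1 `COc1ccc(-c2c(S(=O)(=O)c3ccc(F)cc3)cnc3cc(F)ccc23)cc1` gives 1.77 mL/min
compound 2 `O=S(=O)(c1ccc(F)cc1)c1cnc2cc(F)ccc2c1-c1ccc(F)cc1` gives 1.34 mL/min
compound 3 `O=S(=O)(c1cc(Cl)cc(Cl)c1)c1cnc2cc(F)ccc2c1-c1cccc(F)c1` gives 0.41 mL/min

All three were tested in an ADME assay on microsomes from liver (Homo sapiens) for metabolic stability, tested at 2.5 uM; on this read-out higher numbers stand for fast clearance and lower numbers for slow clearance. Compound 1 and compound 2 share a core and differ in one spot: methoxy in place of fluoro on an aromatic carbon. That change gave a 1.3-fold higher number from compound 2 to compound 1 (0.12 log units; within the scatter), so the two numbers cannot be told apart. Compound 3 has a different core; how it differs from compound 2 is not broken down here. In this assay compound 3 stands lowest of the three, and its distance from both compound 1 and compound 2 lies beyond the scatter.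

Compound 4 `COc1cccc(-c2c(S(=O)(=O)c3cc(Cl)cc(Cl)c3)cnc3cc(F)ccc23)c1` has not yet been measured. It differs from compound 3 in this way: methoxy in place of fluoro on an aromatic carbon. Within the data shown here, this is the same kind of change as the one from compound 2 to compound 1, not the same, since there the methoxy sits para to a large group, here meta to a large group.

The expectation for compound 4 rests on compound 3, because its value 0.41 mL/min is the starting point, and on the earlier swap, because a 1.3-fold higher number from compound 2 to compound 1 (0.12 log units; within the scatter) was within the scatter. The step from compound 3 to compound 4 is therefore estimated to be small, a 1.3-fold higher number from compound 3 to compound 4 (0.10 log units; within the scatter), with the different place around the change adding some uncertainty. Compound 4 is thus expected to show about 0.52 mL/min, most likely between 0.28 mL/min and 0.95 mL/min.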

Compound 4, intrinsic clearance in a liver preparation (reported as CLH), per the amount of preparation that the assay uses: 1.51 mL/min
Compound 4: the middle estimate sits 2.9-fold (0.46 log units) below what was measured; the measured number lies above the stated range.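

In this assay, methoxy in place of fluoro gave a 3.7-fold higher number from compound 3 to compound 4 (0.57 log units; beyond the scatter), a step on the core of compound 3 that stands clearly apart from the usual noise of the measurement. Set beside the earlier case, this shows that the size of the swap did not carry over from one core to the other: the same change on two cores in this assay, a 1.3-fold higher number (0.12 log units; within the scatter) from compound 2 to compound 1 and a 3.7-fold higher number (0.57 log units; beyond the scatter) from compound 3 to compound 4, 2.8-fold (0.45 log units) apart, beyond the scatter of two such steps. A newcomer might read this as a rule that methoxy always raises clearance, but the pairs do not show that: one of the two steps is too small to read, and the two pairs differ both in the core around the change and in where the methoxy sits, so these two influences cannot be separated.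

The compounds shown leave open whether the larger step on the core of compound 3 belongs to methoxy in particular, or whether a hydroxy, an ethoxy, a chloro or a nitrile on the same aromatic carbon would also lift the number well away from that of compound 3. They also leave open how the swap would behave on a third core, such as one that carries an amine or a carboxylic acid.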